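Phenyl for Methoxybenzyl on a Shared Core

A few compounds are considered here, and "the series" means these few. Any claim that something is new, unique, unknown or untested is made for them only; others in the source may bear on it.

Compound 1 `CCOC(=O)CN(Cc1ccccc1)c1nc(NCc2cccc(OC)c2)ncc1[N+](=O)[O-]` was tested in a functional assay on A549 cells (Homo sapiens) for antiproliferative activity, read by MTT assay, with a stated time of 48 h (a lower number here means a stronger inhibitor, a higher number a weaker inhibitor), and gave no number, only a limit of > 100000 nM. Compound 1 therefore stands nowhere on a scale of measured values; its result is a limit of the assay and nothing more. Compound 2 `COC(=O)CN(C)c1nc(Nc2ccccc2)ncc1[N+](=O)[O-]`, which shares the same core, gave in this assay likewise only a limit of > 100000 nM. Within the data shown here, the two results together show (the limit of > 100000 nM in this assay, at which 2 of the 2 values shown sit), so no measured step between any pair of compounds is available. Compound 3 `CCOC(=O)CN(Cc1ccccc1)c1nc(Nc2ccccc2)ncc1[N+](=O)[O-]` has not yet been tested. It differs from compound 1 in one place: phenyl in place of 3-methoxybenzyl on a nitrogen on an aromatic ring. With both neighbours of compound 3 in this series sitting at the limit, the step from compound 1 to compound 3 is expected to be a number no higher from compound 1 to compound 3 (the limit leaves the size open), none beyond the scatter, and most likely to end again in a limit rather than a number. The estimate for compound 3 in this assay is 100000 nM, within a range from 30000 nM to 300000 nM.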

Compound 3, half-maximal inhibitory concentration: > 100000 nM
Compound 3 ended at the assay's limit (the forecaster's own chance of this, stated with the estimate: 85%); the middle value sits exactly at the limit.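

In this assay compound 1 and compound 3 both give only a limit of the assay and not a number, so no step can be read between them for phenyl in place of 3-methoxybenzyl. The compounds shown leave open whether any change on the shared core yields a measurable value, since all three sit at one point: the limit of > 100000 nM in this assay, at which 3 of the 3 values shown sit.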